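This account rests on a few compounds, and the source may have more. Where it says the series, first, only, none or still open, it means among the compounds named here.

In a functional assay on DU-145 cells (Homo sapiens) for antiproliferative activity, read by MTT assay, with a stated time of 72 h (on this read-out higher numbers stand for weaker inhibition and lower numbers for stronger inhibition), compound 2 `O=C(COc1ccc(C(=O)/C=C/c2ccc(F)cc2)cc1)N[C@H]1CCOC1=O` gives 18800 nM. Going by the values given here, compound 1 `COc1ccccc1/C=C/C(=O)c1ccc(OCC(=O)N[C@H]2CCOC2=O)cc1` gives 10100 nM, and these are the only two numeric values so far. The two compounds stand level within the scatter. Compound 3 `CC(C)c1ccc(NCC(=O)N[C@H]2CCOC2=O)cc1` returns only a limit, > 64000 nM.

Compound 4 `O=C(COc1ccc(C(=O)/C=C/c2ccccc2Br)cc1)N[C@H]1CCOC1=O` remains to be measured. Its difference from compound 2 is 2-bromophenyl in place of 4-fluorophenyl on a double-bonded chain carbon bound to a double-bonded chain carbon.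

Among the compounds with values here, only one measured step bears on this change. At the same place, 4-fluorophenyl in place of 2-methoxyphenyl gave a 1.9-fold higher number from compound 1 to compound 2 (0.27 log units; within the scatter), which lies within the scatter. That single step is thin support, but it gives no ground for expecting a large shift in this assay. The expected change is therefore none beyond the scatter, with no firm direction: a 1.3-fold lower number from compound 2 to compound 4 (0.13 log units; within the scatter). For compound 4 the estimated value is 14000 nM, with an expected range of 6000 nM to 32000 nM.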

Compound 4, half-maximal inhibitory concentration: 3540 nM
Estimate against measurement, compound 4: 4.0-fold (0.60 log units) above; measured number outside the range, below it.
By their numbers in this assay, from the lowest: compound 4; then compounds 1 and 2 (each within the scatter of the next). At a limit, above all of these: compound 3.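

In this assay this place responds to the change: 2-bromophenyl in place of 4-fluorophenyl gives a 5.3-fold lower number from compound 2 to compound 4 (0.73 log units; beyond the scatter) and bromo in place of methoxy on an aromatic carbon gives a 2.9-fold lower number from compound 1 to compound 4 (0.46 log units; beyond the scatter) in the same direction. Compound 1 and compound 2 had stood level within the scatter, so the earlier step gave no sign that this position could separate compounds; compound 4 now stands apart from both. No measured finding at hand accounts for this shift.

A 4-bromophenyl and a 2-fluorophenyl would separate the contribution of bromo from that of its place on the phenyl ring, which these compounds leave open. Also open, as far as these compounds go, is how a 2-aminophenyl or a 2-carboxyphenyl at this place would read in this assay.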